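Swapping a chloropyridine for a short acid chain

The compounds below may be only part of what the source reports. "The series", "measured", "known", "first", "only" and "open" are said of these compounds alone.

Compound 1 `O=C(c1ccc(Cl)nc1)N1CCC(NS(=O)(=O)c2cc(S(=O)(=O)c3ccccc3)ccc2C(F)(F)F)CC1` is measured in an assay on U2OS cells for inhibition of secreted frizzled-related protein 1 (Homo sapiens), read by a luciferase reporter, with a stated time of 18 h (a lower number here means that less compound is needed, a higher number that more compound is needed for the effect), where it gives 140 nM. Among the three measured compounds it carries the lowest number. Compound 2 `O=C(O)c1cccc(S(=O)(=O)N2CCC(NS(=O)(=O)c3cc(S(=O)(=O)c4ccccc4)ccc3C(F)(F)F)CC2)c1` gives 190 nM, and the step of a 1.4-fold higher number from compound 1 to compound 2 (0.13 log units; within the scatter) lies within the scatter, so the two cannot be told apart. Compound 3 `O=S(=O)(NC1CCN(S(=O)(=O)c2cccc(-c3nnn[nH]3)c2)CC1)c1cc(S(=O)(=O)c2ccccc2)ccc1C(F)(F)F` gives 1200 nM, a clearly higher number than compound 1, reached through the step of a 6.3-fold higher number from compound 2 to compound 3 (0.80 log units; beyond the scatter).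

Compound 4 `O=C(O)CCCC(=O)N1CCC(NS(=O)(=O)c2cc(S(=O)(=O)c3ccccc3)ccc2C(F)(F)F)CC1` has not yet been measured. It differs from compound 1 in one place: 3-carboxypropyl in place of 6-chloropyridin-3-yl on a carbonyl carbon. The change removes the aromatic ring attached to the carbonyl and puts a carboxy group at the end of a short chain instead.

Among the compounds with values here, two measured steps bear on this. The step from compound 1 to compound 2 shows that a group bearing a carboxy on the amide side of the core can sit within the scatter of compound 1. The step from compound 2 to compound 3 shows that altering that acidic end costs a modest amount. Within the data shown here, compound 4 keeps the carboxy but loses the ring entirely, which none of the measured compounds tests, so a modest rise in this assay is expected, the estimated step being a 2.5-fold higher number from compound 1 to compound 4 (0.40 log units; beyond the scatter). For compound 4 the expected value is 350 nM, with a range from 120 nM to 1000 nM.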

Compound 4, half-maximal effective concentration: 570 nM
The estimate for compound 4 lay 1.6-fold (0.21 log units) below the measured number; low and high end bracket the measured number.
By their numbers in this assay, from the lowest: compounds 1 and 2 (each within the scatter of the next); then compound 4; then compound 3.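

Keeping a carboxy group does not by itself preserve the number of compound 1 in this assay: with the ring gone from this carbonyl carbon and 3-carboxypropyl in its place, the result is a 4.1-fold higher number from compound 1 to compound 4 (0.61 log units; beyond the scatter). The ringless acid chain also gives a higher number than the aromatic acid joined through a sulfonyl, with a 3.0-fold higher number from compound 2 to compound 4 (0.48 log units; beyond the scatter), although that step changes the linking group as well as the ring. Still, an aromatic ring is not strictly required here, since the chain gives a modest rise and the effect remains measurable.

As far as these compounds go, whether the rise comes from losing the ring or from the chain itself stays open; a plain alkyl chain without the carboxylic acid, a longer chain acid or a chain ending in an amine would help separate these. Nothing shown here gives a measured reason for the rise.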